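The source may report more compounds than this note shows. Statements on the series, on what has been measured and on what is new or still open speak of the compounds shown alone.

Among the compounds with values here, compound 1 `COc1cc(-c2cc(/C=C/C(=O)c3ccc(N)cc3)[nH]n2)cc(OC)c1OC` is the only compound of this set with a numerical result in a functional assay on MCF7 cells (Homo sapiens) for inhibition, read by sulforhodamine B assay, with a stated time of 48 h; a lower number here means a stronger inhibitor of growth, a higher number a weaker inhibitor of growth: compound 1 gives 5420 nM. Its partner compound 2 `COc1cc(-c2cc(/C=C/C(=O)c3ccc(Cl)c(Cl)c3)[nH]n2)cc(OC)c1OC` reaches only a limit of this assay, as compound 2 gives > 100000 nM. Within the data shown here, the one measured step, an at least 18-fold higher number from compound 1 to compound 2 (1.26 log units; beyond the scatter), involves 3,4-dichlorophenyl in place of 4-aminophenyl on a carbonyl carbon, and it rests on the limit of > 100000 nM in this assay, at which 1 of the 2 values shown sits, rather than on a number.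

Compound 3 `COc1ccc(-c2cc(/C=C/C(=O)c3ccc(N)cc3)[nH]n2)cc1OC` differs from compound 1 elsewhere, by hydrogen in place of methoxy on an aromatic carbon. The measured step concerns the aryl ketone end of the molecule, not the methoxy-bearing ring, so it does not bear directly on this change; it shows only that this assay can move far. Among the measured compounds shown here, with no step on this position, the writer expects a moderate weakening, a 2.2-fold higher number from compound 1 to compound 3 (0.35 log units; beyond the scatter), likely beyond the scatter but well short of the limit. For compound 3 the estimate is 12000 nM, within 4000 nM to 40000 nM.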

Compound 3, concentration for total growth inhibition: 8480 nM
The estimate for compound 3 lay 1.4-fold (0.15 log units) above the measured number; the range from low to high includes it.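

Within the data shown here, this is the first reading on the methoxy-bearing ring, as the earlier step concerned only the aryl ketone end. In this assay, hydrogen in place of methoxy gives a 1.6-fold higher number from compound 1 to compound 3 (0.19 log units; within the scatter), so the two compounds cannot be told apart, and with the 4-aminophenyl ketone kept, this methoxy is not required for a reading of this order. Nothing measured here accounts for the result.

The compounds shown leave open how an ethoxy group, a hydroxyl group or a fluorine atom would read on this carbon, since hydrogen is the only replacement shown there. They also leave open whether the same change would read alike with the 3,4-dichlorophenyl ketone, or whether the other two methoxy groups can be replaced as well.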